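Dimethylamino in Place of Hydrogen on the Five-Membered Ring

The source may report more compounds than this note shows. Statements on the series, on what has been measured and on what is new or still open speak of the compounds shown alone.

Compound 2 `FC(F)(F)c1cccc(N2CCN(C3CCN(c4ccc(-c5ncns5)nn4)CC3)CC2)c1` stands lowest of the two numbers shown: in a functional assay (aorta) for inhibition, with Rattus norvegicus as the target, with a stated time of 8 days (a lower number here means a stronger inhibitor, a higher number a weaker inhibitor), compound 2 gives 0.3 nM, while compound 1 `Cc1nsc(-c2ccc(N3CCN(c4cccc([N+](=O)[O-])c4)CC3)nn2)n1` gives 3 nM, a gap beyond the scatter. Compound 3 `CN(C)c1nsc(-c2ccc(N3CCC(N4CCN(c5cccc(C(F)(F)F)c5)CC4)CC3)nn2)n1` has not yet been measured. The change from compound 2 to compound 3 is dimethylamino in place of hydrogen on an aromatic carbon. Among the measured compounds shown here, no measured pair shows this change on its own, so the expected step from compound 2 to compound 3 is a 1.3-fold higher number from compound 2 to compound 3 (0.12 log units; within the scatter), judged to stay within the scatter. Compound 3 is therefore estimated at 0.4 nM, with a range from 0.1 nM to 1.5 nM.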

Compound 3, half-maximal inhibitory concentration: < 1 nM
Compound 3: no number, only a limit; the forecaster's own chance of this, stated with the estimate: 5%; the middle value is on the limit's open side.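

In this assay, among the compounds shown here, compound 3 gives < 1 nM, which is a limit and not a number, so no step from compound 2 to compound 3 can be read. The compounds shown leave open whether dimethylamino in place of hydrogen changes the number in this assay, and in which direction.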